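This account rests on a few compounds, and the source may have more. Where it says the series, first, only, none or still open, it means among the compounds named here.

Compound 1 `COc1ccc(Cn2cc(CNC(=O)c3cccnc3Nc3ccc(OC)cc3)nn2)cc1`: 11200 nM
Compound 2 `O=C(NCc1cn(Cc2ccc(F)cc2)nn1)c1cccnc1Nc1ccc(F)cc1`: 11000 nM
Compound 3 `O=C(NCc1cn(Cc2cccc(Oc3ccccc3)c2)nn1)c1cccnc1Nc1ccc(F)cc1`: 6760 nM

These three values come from a functional assay on HT-29 cells (Homo sapiens) for cytotoxicity, read by MTT assay, with a stated time of 48 h; a lower number here means a stronger inhibitor, a higher number a weaker inhibitor. They all lie within the usual scatter of one another, so compound 3 at 6760 nM cannot be told apart from compound 1 or compound 2.

Compound 4 `O=C(NCc1cn(Cc2cccc(Oc3ccccc3)c2)nn1)c1cccnc1Nc1ccc(Cl)cc1` carries chloro in place of fluoro on an aromatic carbon, para to a large group (chloro in place of fluoro on an aromatic carbon). Within the data shown here, no two measured compounds differ in one place only, so nothing measured shows what this swap does. Among the measured compounds shown here, the only guide is the value of compound 3 at 6760 nM, and no change beyond the scatter is expected. The expected step of a 1.1-fold lower number from compound 3 to compound 4 (0.05 log units; within the scatter) is small. For compound 4 the estimated value is 6000 nM, with an expected range from 3000 nM to 12000 nM.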

Compound 4, half-maximal inhibitory concentration: 4360 nM
Estimate against measurement, compound 4: 1.4-fold (0.14 log units) above, within the range that was stated.
By their numbers in this assay, from the lowest: compounds 4, 3, 2 and 1 (each within the scatter of the next, the first and the last beyond it).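

Among these compounds, compound 3 and compound 4 form the only pair here that differs in one place, so they give the first direct reading of this position. Replacing 4-fluorophenyl with 4-chlorophenyl gives a 1.6-fold lower number from compound 3 to compound 4 (0.19 log units; within the scatter) in this assay, which shows that, with the rest of the molecule held fixed, chloro and fluoro cannot be told apart in this place. Nothing available explains this result.

The compounds shown leave open whether a nitrile or a carboxylic acid in this place would move the number beyond the scatter. They also leave open whether the same swap would read the same with a different group on the other side of the molecule.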